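Compound 3 to compound 4: methyl to ethyl

The compounds below may be only part of what the source reports. "The series", "measured", "known", "first", "only" and "open" are said of these compounds alone.

Measured in a functional assay on K562 cells (Homo sapiens) for cytotoxicity, with a stated time of 72 h; a lower number here means a stronger inhibitor, a higher number a weaker inhibitor:
compound 1 `Cc1cccc(-c2nn3c(c2-c2ccnc(Cl)c2)CC(C)(C)C3)n1`: > 100000 nM, a limit
compound 2 `Cc1cccc(-c2nn3c(c2-c2ccnc(Nc4ccc(S(N)(=O)=O)cc4)c2)C(C)C(C)(C)C3)n1`: 31000 nM
compound 3 `Cc1cccc(-c2nn3c(c2-c2ccnc(Cl)c2)C(C)C(C)(C)C3)n1`: > 100000 nM, a limit

Compound 3 has no exact number, only a limit: it sits at the limit of > 100000 nM in this assay, at which 2 of the 3 values shown sit. Compound 4 `CCc1cccc(-c2nn3c(c2-c2ccnc(Cl)c2)C(C)C(C)(C)C3)n1` differs from it by methyl in place of hydrogen on a saturated chain carbon bound to an aromatic carbon, so 6-methylpyridin-2-yl becomes 6-ethylpyridin-2-yl. Within the data shown here, no measured step touches this place. The nearest one, also an added methyl but on a saturated ring carbon, is a step that the two limits leave unreadable from compound 1 to compound 3. The other, an at least 3.2-fold higher number from compound 2 to compound 3 (0.50 log units; beyond the scatter), brought in the chloro that compound 4 keeps. No step beyond the scatter is therefore expected in this assay. The expected size is a number no higher from compound 3 to compound 4 (the limit leaves the size open). For compound 4 the estimate is 100000 nM, with an expected range of 60000 nM to 200000 nM.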

Compound 4, half-maximal inhibitory concentration: 82000 nM
Compound 4: the middle estimate sits 1.2-fold (0.09 log units) above what was measured; the range from low to high includes it.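

In this assay, the first change shown at this position, 6-methylpyridin-2-yl to 6-ethylpyridin-2-yl, gives an at least 1.2-fold lower number from compound 3 to compound 4 (0.08 log units; that floor lies within the scatter). As far as these compounds go, the size of this step stays open, but the ethyl group does not raise the number. Among the compounds carrying the chloro, compound 4 alone has an exact number, while the others rest on a limit: the limit of > 100000 nM in this assay, at which 2 of the 4 values shown sit.

From the compounds shown here alone, what a longer chain such as propyl, or an amine, would do at this place remains open. So does whether (4-sulfamoylphenyl)amino in place of the chloro would lower the number alongside the ethyl group.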